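Removing bromo from the compound with the lowest of three numbers

The compounds below may be only part of what the source reports. "The series", "measured", "known", "first", "only" and "open" are said of these compounds alone.

Measured so far:
- compound 1 `COc1ccc(/C(Cl)=C/C=C(\C#N)C(=O)c2c(C)[nH]c3ccccc23)cc1`: 34.2%
- compound 2 `COc1ccc(/C(Cl)=C/C=C(\C#N)C(=O)c2c[nH]c3ccc(Br)cc23)cc1`: 15.6%
- compound 3 `COc1cc(/C(Cl)=C/C=C(\C#N)C(=O)c2c[nH]c3ccc(Br)cc23)cc(OC)c1OC`: 26.3%

These three compounds were tested in a functional assay for inhibition, with a stated time of 30 min, tested at 1 mM; on this read-out higher numbers stand for more inhibition at the one concentration tested (going by the name of the read-out) and lower numbers for less inhibition. Compound 2 gives the lowest of the three numbers; compound 3 lies above it by a gap beyond the scatter, and compound 1 further above still, also beyond the scatter.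

Compound 4 `COc1ccc(/C(Cl)=C/C=C(\C#N)C(=O)c2c[nH]c3ccccc23)cc1` has not yet been measured. It differs from compound 2 in one place: hydrogen in place of bromo on an aromatic carbon. Among the measured compounds shown here, no pair of measured compounds differs by this change alone, so its effect must be guessed. Since compound 1, which also lacks bromo, gives 34.2%, a modest increase is expected, of a size near the scatter. Compound 4 is therefore estimated at 23%, within 9% to 40%, a step of a number 7.4 percentage points higher from compound 2 to compound 4 (within the scatter).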

Compound 4, a percentage reported as inhibition, at one concentration (the size of the read-out at that concentration, not a potency): 23.4%
The estimate for compound 4 lay 0.4 percentage points below the measured number; measured number inside the range.
By their numbers in this assay, from the lowest: compounds 2, 4, 3 and 1 (each within the scatter of the next, the first and the last beyond it).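

In this assay, the change from bromo to hydrogen on the aromatic carbon gives a number 7.8 percentage points higher from compound 2 to compound 4 (within the scatter), so bromo at this position is not shown to matter. Hydrogen in place of methyl on an aromatic carbon gives a number 10.8 percentage points lower from compound 1 to compound 4 (beyond the scatter), the first single change here that clearly exceeds the scatter. Nothing available explains either step. Going by these compounds, whether an amine or a carboxylic acid on the carbon that carries bromo would shift the number beyond the scatter remains open.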